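The source may report more compounds than this note shows. Statements on the series, on what has been measured and on what is new or still open speak of the compounds shown alone.

In a functional assay on A-375 cells (Homo sapiens) for antiproliferative activity, read by MTT assay, with a stated time of 72 h (on this read-out higher numbers stand for weaker inhibition and lower numbers for stronger inhibition), compound 1 (`COc1ncc(-c2ccc3c(c2)N(c2ccc(C)cc2)C(=O)CO3)cc1NS(=O)(=O)c1ccc(F)cc1`) gives 12900 nM and holds the lower of the two actual numbers. Compound 3 (`Cc1ccc(N2C(=O)COc3ccc(-c4cnc(Cl)c(NS(=O)(=O)c5ccc(F)cc5)c4)cc32)cc1`) gives 38900 nM in this assay. Compound 2 (`O=C1COc2ccc(-c3cnc(Cl)c(NS(=O)(=O)c4ccc(F)cc4)c3)cc2N1C1CCCCC1`) reaches only a limit of the assay, > 40000 nM, and not a number. Compound 4 (`COc1ccc(N2C(=O)COc3ccc(-c4cnc(OC)c(NS(=O)(=O)c5ccc(F)cc5)c4)cc32)cc1`) departs from compound 1 by one change, (methoxy in place of methyl on an aromatic carbon), in which 4-methylphenyl becomes 4-methoxyphenyl. For the measured compounds named here, no measured step makes this exchange. The closest is an at least 1.0-fold lower number from compound 2 to compound 3 (0.01 log units; that floor lies within the scatter), which concerns the group on the same amide-type nitrogen, replacing cyclohexyl with 4-methylphenyl, but it gives only a floor. The other, a 3.0-fold higher number from compound 1 to compound 3 (0.48 log units; beyond the scatter), is modest and comes from chloro in place of methoxy at a different aromatic carbon, so it says little about this change. With nothing measured for the new group, no shift in either direction can be argued, and the expected step, a 1.1-fold higher number from compound 1 to compound 4 (0.04 log units; within the scatter), is none beyond the scatter. For compound 4 the expected value is 14000 nM, with an estimated range from 5500 nM to 34000 nM in this assay.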

Compound 4, half-maximal inhibitory concentration: 18400 nM
Compound 4: the middle estimate sits 1.3-fold (0.12 log units) below what was measured; the range from low to high includes it.
By their numbers in this assay, from the lowest: compounds 1 and 4 (each within the scatter of the next); then compound 3. At a limit, above all of these: compound 2.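

In this assay, replacing 4-methylphenyl with 4-methoxyphenyl on the amide-type nitrogen gives a 1.4-fold higher number from compound 1 to compound 4 (0.15 log units; within the scatter) and so shows that methoxy can take the place of methyl on this aromatic carbon without a step beyond the scatter. For the compounds shown here, earlier, the only step at this nitrogen rested on the limit of compound 2, whereas both ends of this step are actual numbers. No evidence given here bears on this result.

As far as these compounds go, whether an amine, a carboxylic acid or a longer chain on this same aromatic carbon would also stay within the scatter of compound 1 remains open. Also open, from the compounds shown here alone, is whether 4-methoxyphenyl would give the same picture with the chloro group of compound 3 in place of the methoxy group on the other ring.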